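The source may hold more compounds than are shown below. What is called first, only, known or untested is meant among the compounds shown, and "the series" means these compounds.

Values in a functional assay on HCT-116 cells (Homo sapiens) for inhibition, read by colorimetric assay, with a stated time of 3 days (on this read-out lower numbers stand for stronger inhibition and higher numbers for weaker inhibition), so far:
- compound 1 `O=C(CCCCCCNC(=O)C(O)(O)C(F)(F)F)Nc1ccccc1Br` gives 14500 nM
- compound 2 `COc1ccc(NC(=O)CCCCCCNC(=O)C(O)(O)C(F)(F)F)cc1` gives 4520 nM
- compound 3 `O=C(CCCCCCNC(=O)C(O)(O)C(F)(F)F)Nc1nc(-c2ccccc2)c(-c2ccccc2)s1` gives 29900 nM

Of these three, compound 2 has the lowest number, with compound 1 next and compound 3 highest. Compound 4 `O=C(CCCCCCNC(=O)C(O)(O)C(F)(F)F)Nc1ccc(Br)cc1` has not yet been measured. Relative to compound 2, it has bromo in place of methoxy on an aromatic carbon, para to a large group (bromo in place of methoxy on an aromatic carbon).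

Going by the values given here, only one measured step bears on this change, and only loosely. That step, a 3.2-fold lower number from compound 1 to compound 2 (0.51 log units; beyond the scatter), is modest but beyond the scatter. It alters both the group and its place on the ring, so it does not separate the two. Among the compounds with values here, compound 3 offers no single-place step to compare. Compound 4 has bromo in common with compound 1 and keeps the ring place of the methoxy in compound 2, so a number between those of compound 2 and compound 1 seems the reasonable expectation.

The expected step is a 1.5-fold higher number from compound 2 to compound 4 (0.19 log units; within the scatter) in this assay, an estimate leaning towards a higher number but not expected to clear the scatter. Compound 4 is estimated at 7000 nM with an expected range of 2500 nM to 20000 nM as the working expectation.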

Compound 4, half-maximal inhibitory concentration: 3130 nM
Beside the measured number, compound 4's estimate is 2.2-fold (0.35 log units) above it; the range from low to high includes it.
By their numbers in this assay, from the lowest: compounds 4 and 2 (each within the scatter of the next); then compound 1; then compound 3.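

In this assay, methoxy and bromo on an aromatic carbon, para to a large group, are not told apart (a 1.4-fold lower number from compound 2 to compound 4 (0.16 log units; within the scatter)), so this place tolerates either group in this read-out, at least for these two. The bromo pair separates what the earlier step could not, since only the place of the bromo differs (a 4.6-fold lower number from compound 1 to compound 4 (0.67 log units; beyond the scatter)); the earlier step (a 3.2-fold lower number from compound 1 to compound 2 (0.51 log units; beyond the scatter)) changed both group and place, and its size now looks attributable largely to place rather than to the group itself. Nothing available explains either the difference between the two bromo places or the lack of one between the two groups at the same place.

Going by these compounds alone, with only methoxy and bromo at this place and only two ring places for bromo, it remains open whether an amine, a carboxylic acid or a plain unsubstituted phenyl would stay level with compound 2 and compound 4. As far as these compounds go, it is also open whether the place effect seen for bromo holds for methoxy, and whether a longer chain in the shared core would alter these steps.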